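The source may hold more compounds than are shown below. What is called first, only, known or untested is meant among the compounds shown, and "the series" means these compounds.

Compound 1 `COc1ccc(NC(=O)c2cc(OC)c(OC)c(OC)c2)cc1[N+](=O)[O-]` gives, in a functional assay on HeLa cells (Homo sapiens) for antiproliferative activity, read by MTT assay, with a stated time of 72 h (on this read-out higher numbers stand for weaker inhibition and lower numbers for stronger inhibition), a value of 38700 nM. Compound 2 `COc1ccc(NC(=O)c2cc(OC)c(OC)c(OC)c2)cc1N` differs from it by amino in place of nitro on an aromatic carbon, and in this assay compound 2 gives 4100 nM, a step of a 9.4-fold lower number from compound 1 to compound 2 (0.97 log units; beyond the scatter). Compound 3 `COc1ccc(C(=O)Nc2cc(OC)c(OC)c(OC)c2)cc1[N+](=O)[O-]` is built from the same atoms as compound 1, joined differently; the difference between the two cores is not broken down here. In this assay compound 3 gives 3700 nM. Compound 4 `COc1ccc(C(=O)Nc2cc(OC)c(OC)c(OC)c2)cc1N` differs from compound 3 by amino in place of nitro on an aromatic carbon, the same change already seen, at the same kind of position. Because the earlier step was a 9.4-fold lower number from compound 1 to compound 2 (0.97 log units; beyond the scatter), the step is expected to be a 6.2-fold lower number from compound 3 to compound 4 (0.79 log units; beyond the scatter). On that basis, compound 4 is estimated at 600 nM, expected to fall between 150 nM and 2500 nM.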

Compound 4, half-maximal inhibitory concentration: > 100000 nM
Compound 4: no number, only a limit (the forecaster's own chance of this, stated with the estimate: 2%); at least 160-fold (2.22 log units) between middle value and limit.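

In this assay compound 4 gives > 100000 nM, which is a limit of the assay and not a number. Amino in place of nitro therefore gives an at least 27-fold higher number from compound 3 to compound 4 (1.43 log units; beyond the scatter), so on these two cores the change does not carry over, in either direction or size: the same change on two cores in this assay, a 9.4-fold lower number (0.97 log units; beyond the scatter) from compound 1 to compound 2 and an at least 27-fold higher number (1.43 log units; beyond the scatter) from compound 3 to compound 4, at least 250-fold (2.40 log units) apart, beyond the scatter of two such steps The true size of the new step stays unknown, and two cores cannot show why the change behaves differently on each, so no general rule follows: the limit of > 100000 nM in this assay, at which 1 of the 4 values shown sits.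

The compounds shown leave open how a carboxylic acid or a methylamino group at the same place would behave on each core. They also leave open whether either result would hold on a third core.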